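Swapping Benzyl for Butoxy on an Aryl Urea

This account rests on a few compounds, and the source may have more. Where it says the series, first, only, none or still open, it means among the compounds named here.

Compound 1 `Nc1nn(C(=O)Nc2ccc(Cc3ccccc3)cc2)c2ccccc12`: 22800 nM
Compound 2 `COc1ccc(NC(=O)Nc2n[nH]c3ccccc23)cc1`: > 100000 nM

Within the data shown here, in a functional assay on SNB-19 cells (Homo sapiens) for inhibition, read by sulforhodamine B assay, with a stated time of 48 h (a lower number here means a stronger inhibitor of growth, a higher number a weaker inhibitor of growth), compound 1 gives 22800 nM, the only true number in this small set. Compound 2 gives > 100000 nM, which is a limit of the assay and not a number. Compound 3 `CCCCOc1ccc(NC(=O)n2nc(N)c3ccccc32)cc1` differs from compound 1 by one change: butoxy in place of benzyl on an aromatic carbon. Among the measured compounds shown here, no measured pair here shows how such an exchange shifts growth inhibition. The step from compound 1 to compound 3 is expected to be modest, at a 1.3-fold higher number from compound 1 to compound 3 (0.12 log units; within the scatter), inside the usual scatter. Compound 3 is therefore estimated at 30000 nM, within a range from 8000 nM to 100000 nM.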

Compound 3, concentration for 50% growth inhibition: 42700 nM
Compound 3: the middle estimate sits 1.4-fold (0.15 log units) below what was measured; the measured number falls inside the stated range.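

On an aromatic carbon para to a large group, butoxy in place of benzyl gives a 1.9-fold higher number from compound 1 to compound 3 (0.27 log units; within the scatter) in this assay. Among these compounds, the first measured step at this position therefore shows that the benzyl ring can be replaced by an open chain without a shift beyond the scatter. The value of compound 2 is a limit of the assay and not a number: the limit of > 100000 nM in this assay, at which 1 of the 3 values shown sits.

Going by these compounds, whether an amine, a carboxylic acid or a longer chain such as hexyloxy at this position would move the number beyond the scatter remains open.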